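The source may report more compounds than this note shows. Statements on the series, on what has been measured and on what is new or still open speak of the compounds shown alone.

Measured so far:
compound 1 `Nc1ncn(CCC2(N)OC(=O)C(OCc3ccccc3)=C2OCc2ccccc2)c(=O)n1`: > 100000 nM
compound 2 `O=C1O/C(=C\Cn2ncc(=O)[nH]c2=O)C(OCc2ccccc2)=C1OCc1ccccc1`: 3770 nM

Of the compounds shown here, two have been tested in a functional assay on MCF7 cells (Homo sapiens) for inhibition, read by MTT assay, with a stated time of 72 h; on this read-out lower numbers stand for stronger inhibition and higher numbers for weaker inhibition. For compound 1 the result is not a number but a limit of the assay, > 100000 nM. Going by the values given here, compound 2 gives 3770 nM, the only actual number in this set. The remaining entry is the limit of > 100000 nM in this assay, at which 1 of the 2 values shown sits. Compound 3 `Nc1ncn(C/C=C2\OC(=O)C(OCc3ccccc3)=C2OCc2ccccc2)c(=O)n1` has not yet been measured. It differs from compound 2 in a single place: a group of 8 heavy atoms (3 carbon, 4 nitrogen, 1 oxygen; one six-membered aromatic ring with 3 hetero atoms) in place of a group of 8 heavy atoms (3 carbon, 3 nitrogen, 2 oxygen; one six-membered aromatic ring with 3 hetero atoms), on a saturated chain carbon bound to a double-bonded chain carbon. Among the compounds with values here, no step between two measured compounds that differ in one place exists here, so there is no measured precedent for this swap, and its direction in this assay cannot be read off the data. On balance a modest weakening is expected, with an estimated step of a 2.7-fold higher number from compound 2 to compound 3 (0.42 log units; beyond the scatter), which may or may not exceed the usual scatter. For compound 3 the estimate in this assay is 10000 nM, within 2000 nM to 60000 nM.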

Compound 3, half-maximal inhibitory concentration: 3490 nM
For compound 3 the middle estimate is 2.9-fold (0.46 log units) above the measured one; low and high end bracket the measured number.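

In this assay, the change at this place, on a saturated chain carbon bound to a double-bonded chain carbon, now has a measured step, and that step is small: it is a 1.1-fold lower number from compound 2 to compound 3 (0.03 log units; within the scatter) for the new group. Putting the group of 3 carbon, 4 nitrogen and 1 oxygen where the group of 3 carbon, 3 nitrogen and 2 oxygen stood gives a read-out that cannot be told apart from the earlier one, so on this shared core the two ring groups behave alike in this test. Nothing measured here explains why the swap makes so little difference.

From the compounds shown here alone, how an amine, a carboxylic acid or a longer chain at this place would read stays open. Also open, going by these compounds, is whether the match between these two ring groups would hold on a different core.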